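Cyclic imide in place of diacetylamino: expected outcome

The source may report more compounds than this note shows. Statements on the series, on what has been measured and on what is new or still open speak of the compounds shown alone.

Measured so far:
compound 1 `CC(=O)N(C(C)=O)C1=C(C#N)C(c2ccc(Cl)cc2)C2=C(CC(C)(C)CC2=O)N1c1ccc(S(N)(=O)=O)cc1` — 72100 nM
compound 2 `CCO/C=N/C1=C(C#N)C(c2ccc(Cl)cc2)C2=C(CC(C)(C)CC2=O)N1c1ccc(S(N)(=O)=O)cc1` — 97200 nM

Compound 1 has the lowest of the two numbers in a functional assay on MCF7 cells (Homo sapiens) for antiproliferative activity, read by sulforhodamine B assay, with a stated time of 48 h (a higher number here means a weaker inhibitor, a lower number a stronger inhibitor), but its nearest neighbour compound 2 differs only by a 1.3-fold higher number from compound 1 to compound 2 (0.13 log units; within the scatter), so the two cannot be ranked. That single step is the only one recorded, and it sits at the same double-bonded ring carbon that is varied here.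

Compound 3 `CC1(C)CC(=O)C2=C(C1)N(c1ccc(S(N)(=O)=O)cc1)C(N1C(=O)CCC1=O)=C(C#N)C2c1ccc(Cl)cc1` differs from compound 1 by 2,5-dioxopyrrolidin-1-yl in place of diacetylamino on a double-bonded ring carbon. Within the data shown here, the one relevant step, from compound 1 to compound 2, swapped a non-ring group for another at this carbon and stayed within the scatter; nothing measured points in either direction for a ring-closed group of the same atom count. The step of a 1.0-fold higher number from compound 1 to compound 3 (0.02 log units; within the scatter) is therefore expected to be none beyond the scatter. Compound 3 is estimated at 75000 nM in this assay, with a range of 35000 nM to 160000 nM.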

Compound 3, half-maximal inhibitory concentration: 95200 nM
For compound 3 the middle estimate is 1.3-fold (0.10 log units) below the measured one, and the stated range covers the measured number.
By their numbers in this assay, from the lowest: compounds 1, 3 and 2 (each within the scatter of the next).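

In this assay, tying the diacetylamino group into a ring as 2,5-dioxopyrrolidin-1-yl on the double-bonded ring carbon, with the same heavy atoms, gives a 1.3-fold higher number from compound 1 to compound 3 (0.12 log units; within the scatter). Against the open group of compound 2, the ring gives a 1.0-fold lower number from compound 2 to compound 3 (0.01 log units; within the scatter). This position therefore now has a ring-closed group as well as two open ones, and all three steps among them lie within the scatter, so ring closure alone shows no effect on the number in this series. No further data bear on this result.

Going by these compounds, whether any group on this carbon can move the number beyond the scatter remains open, for example a free amine or a carboxylic acid. The compounds shown also share the 4-chlorophenyl and 4-sulfamoylphenyl groups, so they say nothing about changes at those places.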